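This account rests on a few compounds, and the source may have more. Where it says the series, first, only, none or still open, it means among the compounds named here.

Compound 3 `COc1cc(-c2ncnn2-c2ccc(Cl)cc2Cl)cc(OC)c1OC` sits at a limit of a functional assay on MCF7 cells (Homo sapiens) for antiproliferative activity, read by MTT assay, with a stated time of 72 h; on this read-out higher numbers stand for weaker inhibition and lower numbers for stronger inhibition: in this assay compound 3 gives > 10000 nM. Compound 2 `COc1cc(-c2ncnn2-c2ccc(Cl)c(Cl)c2)cc(OC)c1OC` also sits at a limit, giving > 10000 nM. Compound 1 `COc1ccc(-n2ncnc2-c2cc(OC)c(OC)c(OC)c2)cc1` gives a number, 7400 nM. Two of the three values share one limit (the limit of > 10000 nM in this assay, at which 2 of the 3 values shown sit). Exchanging the 4-methoxyphenyl for dichlorophenyls produced an at least 1.3-fold higher number from compound 1 to compound 2 (0.13 log units; that floor lies within the scatter) and an at least 1.3-fold higher number from compound 1 to compound 3 (0.13 log units; that floor lies within the scatter), floors that lie within the scatter, while a step that the two limits leave unreadable from compound 2 to compound 3 stays unreadable. Compound 4 `COc1cc(-c2ncnn2-c2ccc(N)cc2)cc(OC)c1OC` differs from compound 3 in one place: 4-aminophenyl in place of 2,4-dichlorophenyl on an aromatic nitrogen. A phenyl bearing one group thus returns, as in compound 1. Since compound 1 gives 7400 nM, compound 4 is expected at about 7000 nM, within 2000 nM to 20000 nM. The expected step is an at least 1.4-fold lower number from compound 3 to compound 4 (0.15 log units; that floor lies within the scatter), though a limit may again be reported.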

Compound 4, half-maximal inhibitory concentration: > 10000 nM
Compound 4: no number, only a limit (the forecaster's own chance of this, stated with the estimate: 40%); at least 1.4-fold (0.15 log units) between middle value and limit.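

Placing 4-aminophenyl on the aromatic nitrogen, with its hydrogen-bond donor, still yields only a limit for compound 4, so the steps to compound 2 and compound 3 cannot be read. Amino in place of methoxy on an aromatic carbon gives an at least 1.3-fold higher number from compound 1 to compound 4 (0.13 log units; that floor lies within the scatter). Only compound 1 now has a number in this assay, so the other three cannot be ranked: the limit of > 10000 nM in this assay, at which 3 of the 4 values shown sit.

From the compounds shown here alone, whether a 4-hydroxyphenyl or a 4-ethoxyphenyl on that nitrogen would give a clearly lower number than compound 1 stays open.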